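A few compounds are considered here, and "the series" means these few. Any claim that something is new, unique, unknown or untested is made for them only; others in the source may bear on it.

Measured in a functional assay on L1210 cells (Mus musculus) for antiproliferative activity; on this read-out higher numbers stand for weaker inhibition and lower numbers for stronger inhibition:

- compound 1 `Oc1cccc2nccc(O)c12`: > 40000 nM
- compound 2 `COc1ccc(O)c2c(=O)ccn(C)c12`: > 40000 nM
- compound 3 `COc1cc2c(=O)ccn(C)c2cc1OC`: > 40000 nM

Each of these entries is a limit of the assay and not a number. Compound 1 stands at > 40000 nM, which is a limit. It shares this position with the other two compounds, as the record shows: the limit of > 40000 nM in this assay, at which 3 of the 3 values shown sit. Among the compounds with values here, the starting point is therefore not an exact potency, and no measured pair here shows what a single change does.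

Compound 4 `COc1cc(O)c2c(O)ccnc2c1` keeps the core of compound 1 and makes one change: methoxy in place of hydrogen on an aromatic carbon, (methoxy in place of hydrogen on an aromatic carbon). Within the data shown here, with no measured step to guide it, the expectation in this assay is no step beyond the usual scatter, in either direction. The estimated change a number no higher from compound 1 to compound 4 (the limit leaves the size open) is accordingly small, and a further reading at the limit is the likeliest outcome. For compound 4 the expected value is 40000 nM, with an estimated range of 15000 nM to 80000 nM.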

Compound 4, half-maximal inhibitory concentration: > 40000 nM
Compound 4 gave a limit, no number (the forecaster's own chance of this, stated with the estimate: 80%); the middle value lies on the limit itself.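

Compound 4, like compound 1, gives only a limit and not a number, so the methoxy in place of hydrogen yields no readable step: the limit of > 40000 nM in this assay, at which 4 of the 4 values shown sit. The compounds shown leave open which change, if any, would bring a measurable potency against these cells.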